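The source may hold more compounds than are shown below. What is called first, only, known or untested is meant among the compounds shown, and "the series" means these compounds.

Three phenyl-bearing amino-diols have been measured in an assay on isolated protein for inhibition of lysosomal alpha-glucosidase (Rattus norvegicus), read by colorimetric assay; on this read-out lower numbers stand for stronger inhibition and higher numbers for weaker inhibition. Compound 2 `OC[C@]1(c2ccccc2)NC[C@H](O)[C@H]1O` gives 190 nM. Compound 1 `OC[C@@]1(c2ccc(F)cc2)NC[C@@H](O)[C@@H]1O`, which carries fluorine on the aromatic ring, gives 12000 nM. Compound 3 `COc1cccc([C@]2(CO)NC[C@@H](O)[C@@H]2O)c1` gives 52000 nM, the highest of the three numbers; compound 1 stands nearest to it and compound 2 furthest, and both gaps lie beyond the scatter.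

The next compound, compound 4 `OC[C@@]1(c2ccccc2)NC[C@@H](O)[C@@H]1O`, differs from compound 3 in one place: hydrogen in place of methoxy on an aromatic carbon. Compound 4 holds its groups in the same spatial arrangement as compound 1 and compound 3, whereas compound 2 is its mirror image, so compound 2 is not the closest guide.

Going by the values given here, no measured pair shows this exact change, so its size can only be estimated. Compound 1, which has the same spatial arrangement and only fluorine on the ring, gives 12000 nM, which suggests that removing the methoxy group from compound 3 lowers the number without approaching compound 2. The expected step is a 5.2-fold lower number from compound 3 to compound 4 (0.72 log units; beyond the scatter). Compound 4 is therefore estimated to give 10000 nM, with a range from 3000 nM to 40000 nM.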

Compound 4, half-maximal inhibitory concentration: 904000 nM
Compound 4: middle estimate off by 90-fold (1.96 log units), on the low side; the whole stated range lies below it.
By their numbers in this assay, from the lowest: compound 2; then compound 1; then compound 3; then compound 4.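

In this assay, the largest step, a 4800-fold higher number from compound 2 to compound 4 (3.68 log units; beyond the scatter), has a single source: the fact that compounds 2 and 4 differ only in the configuration as drawn. Within the arrangement shared by compound 1, compound 3 and compound 4, the bare ring gives the highest number, with a 17-fold higher number from compound 3 to compound 4 (1.24 log units; beyond the scatter) for hydrogen in place of methoxy and a 75-fold higher number from compound 1 to compound 4 (1.88 log units; beyond the scatter) for hydrogen in place of fluoro. Until compound 4 there was no unsubstituted partner in this arrangement, so nothing could show that both ring groups go with lower numbers than hydrogen.

On these data alone, it remains open whether methoxy or fluoro would shift the number in the same direction on the arrangement of compound 2. As far as these compounds go, it is also open whether an amine or a longer chain on the aromatic ring would lower the number further.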